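This account rests on a few compounds, and the source may have more. Where it says the series, first, only, none or still open, it means among the compounds named here.

Measured compounds:

compound 1, `O=C(Nc1sc2c(c1C(=O)NNc1ccccc1)CCCCC2)NS(=O)(=O)c1ccccc1` — in a functional assay on MCF7 cells (Homo sapiens) for inhibition, with a stated time of 48 h (a lower number here means a stronger inhibitor of growth, a higher number a weaker inhibitor of growth), compound 1 gives > 100000 nM.
compound 2, `O=C(Nc1sc2c(c1C(=O)NNc1ccc(Br)cc1)CCCCC2)NS(=O)(=O)c1ccccc1` — in this assay compound 2 gives > 100000 nM.

Both numbers are limits of the assay, not measured values. Among the compounds with values here, compound 2 stands at the limit, and the one other value shown is also a limit. Within the data shown here, the single measured step, a step that the two limits leave unreadable from compound 1 to compound 2, is therefore not readable in size; the only evidence on it is the limit of > 100000 nM in this assay, at which 2 of the 2 values shown sit.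

Compound 3, `O=C(Nc1sc2c(c1C(=O)NNc1ccc(Cl)cc1)CCCCC2)NS(=O)(=O)c1ccccc1`, is not yet measured. It differs from compound 2 by chloro in place of bromo on an aromatic carbon, para to a large group. The step from compound 1 to compound 2 bears on this change only in that both ends sit at the limit; nothing shows a step beyond the scatter in either direction. For compound 3 a value at or near the limit is expected, 200000 nM (range 50000 nM to 1000000 nM), which means an estimated step that the limit leaves unreadable from compound 2 to compound 3.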

Compound 3, concentration for 50% growth inhibition: 8300 nM
Compound 3: middle estimate off by 24-fold (1.38 log units), on the high side; measured number below the stated range.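

At the position para to a large group, the series now leaves the limit in this assay: chloro in place of bromo gives an at least 12-fold lower number from compound 2 to compound 3 (1.08 log units; beyond the scatter), and chloro in place of hydrogen gives an at least 12-fold lower number from compound 1 to compound 3 (1.08 log units; beyond the scatter). The change at this position therefore does not follow the mere presence of a halogen, since the bromo of compound 2 and the chloro of compound 3 lie far apart in this read-out. The step between compound 1 and compound 2 still cannot be read, and the evidence on it remains: the limit of > 100000 nM in this assay, at which 2 of the 3 values shown sit.

The compounds shown leave open whether fluoro, methyl or methoxy at this position would match the chloro of compound 3. They also leave open whether chloro elsewhere on the ring, or an amine there, would keep this level of growth inhibition.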